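Swapping methoxy for cyano on the anilino ring

The compounds below may be only part of what the source reports. "The series", "measured", "known", "first", "only" and "open" are said of these compounds alone.

Of the compounds shown here, two sharing one core have been measured so far. Compound 1 `COc1ccc(Nc2nc(NCCCO)c3ccccc3n2)cc1` carries a methoxy group on its outer ring and, in a functional assay on KBVIN cells (Homo sapiens) for antiproliferative activity, read by sulforhodamine B assay, with a stated time of 48 h (on this read-out higher numbers stand for weaker inhibition of growth and lower numbers for stronger inhibition of growth), compound 1 gives 17100 nM. Compound 2 `CNc1nc(Nc2ccc(OC)cc2)nc2ccccc12` has the same methoxy group but a shorter substituent on the other side of the core, and in this assay compound 2 gives 17500 nM. For the measured compounds named here, the only step measured, a 1.0-fold higher number from compound 1 to compound 2 (0.01 log units; within the scatter), changes a saturated chain and says nothing about the outer ring. On the numbers shown, compound 1 stands as the lower of the two values, with compound 2 within the scatter of it, so neither can be called stronger.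

Compound 3 `N#Cc1ccc(Nc2nc(NCCCO)c3ccccc3n2)cc1` is not yet measured. It differs from compound 1 by cyano in place of methoxy on an aromatic carbon. Going by the values given here, no measured step touches this position, so there is no basis for expecting a step in either direction beyond the scatter. Compound 3 is therefore estimated at 15000 nM, with a wide range from 5000 nM to 45000 nM, meaning an expected step of a 1.1-fold lower number from compound 1 to compound 3 (0.06 log units; within the scatter).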

Compound 3, concentration for 50% growth inhibition: 4310 nM
Compound 3: the middle estimate sits 3.5-fold (0.54 log units) above what was measured, outside the stated range (below it).
By their numbers in this assay, from the lowest: compound 3; then compounds 1 and 2 (each within the scatter of the next).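

For the compounds shown here, the group on the outer ring matters in this assay, which the earlier pair could not show, as its only step lay in the chain on the other side of the core. With that chain held fixed, cyano in place of methoxy, on an aromatic carbon para to a large group, gives a 4.0-fold lower number from compound 1 to compound 3 (0.60 log units; beyond the scatter), so this position can shift growth inhibition beyond the usual scatter. The computed counts show that the two groups match in heavy atoms and hydrogen-bond acceptors and that neither carries a net charge, while cyano brings nitrogen and a triple bond where methoxy has oxygen, but nothing measured here explains why the number falls.

Going by these compounds, this is a single swap on a single scaffold, so it remains open whether cyano would give a similar step when paired with the shorter substituent of compound 2. On these data alone, it also remains open how other groups at this position, such as an amine, a carboxylic acid or trifluoromethyl, would compare with cyano and methoxy.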